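The compounds below may be only part of what the source reports. "The series", "measured", "known", "first", "only" and "open" are said of these compounds alone.

Two pairs of amide-linked compounds are compared here on a single property. Compound 1 `COC(=O)c1ccc(NC(=O)c2ccc3ccccc3n2)cc1` is measured in a physicochemical assay for solubility (on this read-out lower numbers stand for lower solubility and higher numbers for higher solubility), where compound 1 gives 25 ug/mL. Compound 2 `NC(=O)c1ccc(NC(=O)c2ccc3ccccc3n2)cc1` differs from it in one spot only, (amino in place of methoxy on a carbonyl carbon), and in this assay compound 2 gives 5 ug/mL. That single change produced a 5.0-fold lower number from compound 1 to compound 2 (0.70 log units; beyond the scatter).

Compound 3 `COC(=O)c1cccc(NC(=O)c2ccc(-c3ccccc3)cc2)c1` is built on a different core, and the difference between the two cores is not broken down here. For compound 3, this assay reports only a limit, < 5 ug/mL. Going by these compounds, that reading sits at the limit of < 5 ug/mL in this assay, at which 1 of the 3 values shown sits, so the true number for compound 3 is unknown beyond the fact that it lies under that threshold.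

Compound 4 `NC(=O)c1cccc(NC(=O)c2ccc(-c3ccccc3)cc2)c1` has not yet been measured. It relates to compound 3 exactly as compound 2 relates to compound 1: the change is amino in place of methoxy on a carbonyl carbon, the same change at the same place. Since compound 3 already sits at the limit, the expected outcome for compound 4 in this assay is a value still lower, most likely once more reported only as a limit, with the step expected to be a step that the limit leaves unreadable from compound 3 to compound 4; this expectation rests on the earlier step of a 5.0-fold lower number from compound 1 to compound 2 (0.70 log units; beyond the scatter). The estimate for compound 4 is 1 ug/mL, with a likely range from 0.3 ug/mL to 5 ug/mL, pending the actual reading.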

Compound 4, solubility: 25 ug/mL
Compound 4: middle estimate off by 25-fold (1.40 log units), on the low side; measured number outside the range, above it.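

In this assay, amino in place of methoxy on a carbonyl carbon did not act the same way on the two cores: on one core the change gave a 5.0-fold lower number from compound 1 to compound 2 (0.70 log units; beyond the scatter), and on the other it gave an at least 5.0-fold higher number from compound 3 to compound 4 (0.69 log units; beyond the scatter). Both steps lie beyond the scatter and run in opposite directions, so in these two pairs the direction of the step on one core did not predict its direction on the other. The pairs show that reversal but not its cause, and the second step gives only a minimum size, because the reading for compound 3 is a limit and not a number: the limit of < 5 ug/mL in this assay, at which 1 of the 4 values shown sits.

Among these compounds, with only two pairs, it stays open which part of the cores goes with the reversal, and whether other cores would follow the first pair, the second, or neither. It also stays open whether a hydroxyl or a dimethylamino group on the same carbonyl carbon would split the two cores in the same way, or whether the reversal is confined to the amino group shown here.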